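This account rests on a few compounds, and the source may have more. Where it says the series, first, only, none or still open, it means among the compounds named here.

Working notes on the series. Compound 1 `COc1ccc(-c2c(S(=O)(=O)c3cccc(F)c3)cnc3cc(F)ccc23)cc1` gives 1.89 mL/min in an ADME assay on microsomes from liver (Homo sapiens) for metabolic stability, tested at 2.5 uM; a higher number here means faster removal of the compound, a lower number slower removal. Compound 2 `COc1ccc(S(=O)(=O)c2cnc3cc(F)ccc3c2-c2ccc(Cl)cc2)cc1` gives 1.28 mL/min in this assay, the lower of the two numbers, with compound 1 the nearest and within the scatter of it. Compound 3 `COc1ccc(-c2c(S(=O)(=O)c3ccc(OC)cc3)cnc3cc(F)ccc23)cc1` has not been measured. It differs from compound 2 in one place: methoxy in place of chloro on an aromatic carbon. Going by the values given here, no step between measured compounds exists for this change, so the step of a 1.3-fold higher number from compound 2 to compound 3 (0.10 log units; within the scatter) is expected to stay within the scatter. Compound 3 is therefore estimated at 1.6 mL/min, in the range 0.8 mL/min to 3.2 mL/min.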

Compound 3, intrinsic clearance in a liver preparation (reported as CLH), per the amount of preparation that the assay uses: 1.18 mL/min
For compound 3 the middle estimate is 1.4-fold (0.13 log units) above the measured one; measured number inside the range.
By their numbers in this assay, from the lowest: compounds 3, 2 and 1 (each within the scatter of the next).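

In this assay the change to methoxy from chloro at this position, para to a large group, gives a 1.1-fold lower number from compound 2 to compound 3 (0.04 log units; within the scatter) and so stays within the scatter. The change on the sulfonyl sulfur to 4-methoxyphenyl from 3-fluorophenyl gives a 1.6-fold lower number from compound 1 to compound 3 (0.20 log units; within the scatter) and also stays within the scatter. Nothing measured on these compounds accounts for either step. Still open, from the compounds shown here alone, is whether an amine, a carboxylic acid or a longer chain at this position would move the number beyond the scatter.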